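A few compounds are considered here, and "the series" means these few. Any claim that something is new, unique, unknown or untested is made for them only; others in the source may bear on it.

Values measured in a functional assay on SGC-7901 cells (Homo sapiens) for antiproliferative activity, read by MTT assay, with a stated time of 72 h; a higher number here means a weaker inhibitor, a lower number a stronger inhibitor:
- compound 1 `COc1ccccc1-c1ccc2ncn(-c3cc(OC)c(OC)c(OC)c3)c2c1`: 5050 nM
- compound 2 `COc1cc(-n2cnc3ccc(-c4ccc(C(C)=O)cc4)cc32)cc(OC)c1OC`: 450 nM
- compound 3 `COc1cc(-n2cnc3ccc(-c4ccc(C)cc4F)cc32)cc(OC)c1OC`: 5650 nM

Compound 3 stands level with compound 1, the two being separated by a 1.1-fold higher number from compound 1 to compound 3 (0.05 log units; within the scatter). Compound 2 stands apart from both, with an 11-fold lower number from compound 1 to compound 2 (1.05 log units; beyond the scatter) and a 13-fold higher number from compound 2 to compound 3 (1.10 log units; beyond the scatter).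

Compound 4 `COc1ccc(-c2ccc3ncn(-c4cc(OC)c(OC)c(OC)c4)c3c2)cc1F` carries 3-fluoro-4-methoxyphenyl in place of the 2-fluoro-4-methylphenyl of compound 3, on an aromatic carbon of the shared core: 3-fluoro-4-methoxyphenyl in place of 2-fluoro-4-methylphenyl on an aromatic carbon. Among the compounds with values here, no measured compound carries the incoming group, so the three steps bear on this change only indirectly. They show that swaps at this place can do nothing or a great deal. Compound 2 marks how low the number has gone here, at 450 nM, while compound 1, with its 2-methoxyphenyl group, gives 5050 nM. A moderate fall is therefore expected in this assay, though one that may not clear the scatter, and well short of the level of compound 2. The estimate amounts to an expected 3.1-fold lower number from compound 3 to compound 4 (0.50 log units; beyond the scatter). For compound 4 the estimated value is 1800 nM, with an expected range of 400 nM to 6500 nM.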

Compound 4, half-maximal inhibitory concentration: 430 nM
The estimate for compound 4 lay 4.2-fold (0.62 log units) above the measured number; the range from low to high includes it.
By their numbers in this assay, from the lowest: compounds 4 and 2 (each within the scatter of the next); then compounds 1 and 3 (each within the scatter of the next).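

Swapping one fluorinated phenyl for another at this place on the shared core can move the number in this assay by a large step, as (a 13-fold lower number from compound 3 to compound 4 (1.12 log units; beyond the scatter)) shows. The low level is also not confined to the 4-acetylphenyl group, since the 3-fluoro-4-methoxyphenyl group stands level with it (a 1.0-fold lower number from compound 2 to compound 4 (0.02 log units; within the scatter)), while a methoxy group alone does not suffice, as the 2-methoxyphenyl group stays well short (a 12-fold lower number from compound 1 to compound 4 (1.07 log units; beyond the scatter)). Nothing at hand explains why these groups differ so widely.

The compounds shown leave open whether the fluorine or the methoxy of the 3-fluoro-4-methoxyphenyl group accounts for the fall, or whether the two must be present together. They also leave open whether an amine or a carboxylic acid on that phenyl ring would hold the number at this level.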